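Compound 4: thiophen-2-yl in place of 4-methoxyphenyl

A few compounds are considered here, and "the series" means these few. Any claim that something is new, unique, unknown or untested is made for them only; others in the source may bear on it.

In a physicochemical assay for lipophilicity, measured as octanol-water partition (a lower number here means a more polar compound, a higher number a more lipophilic compound), compound 3 (`COc1ccc(/C=N/c2ccccc2C(=O)NNc2ccnc3cc(Cl)ccc23)cc1`) gives 5, within the scatter of compound 1 (`O=C(NNc1ccnc2cc(Cl)ccc12)c1ccccc1/N=C/c1ccc(F)cc1`) at 5.18, while compound 2 (`O=C(NNc1ccnc2cc(Cl)ccc12)c1ccccc1/N=C/c1ccc(Cl)cc1Cl`) stands apart at 6.22. Compound 4 (`O=C(NNc1ccnc2cc(Cl)ccc12)c1ccccc1/N=C/c1cccs1`) carries thiophen-2-yl in place of 4-methoxyphenyl on a carbon with a double bond to nitrogen. Within the data shown here, no measured step involves thiophen-2-yl. The closest guide is a number 0.18 log units lower from compound 1 to compound 3 (within the scatter), a step that stays within the scatter. The large steps, a number 1.04 log units higher from compound 1 to compound 2 (beyond the scatter) and a number 1.22 log units lower from compound 2 to compound 3 (beyond the scatter), both involve 2,4-dichlorophenyl, which is absent from compound 3 and compound 4. The expected step is small and downward, a number 0.30 log units lower from compound 3 to compound 4 (within the scatter), with only weak support for its direction. For compound 4 the estimate is 4.7, with an expected range of 4.2 to 5.2.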

Compound 4, partition coefficient: 4.78
Compound 4: the middle estimate sits 0.08 log units below what was measured; measured number inside the range.
By their numbers in this assay, from the lowest: compounds 4, 3 and 1 (each within the scatter of the next, the first and the last beyond it); then compound 2.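

Thiophen-2-yl is the only group here at the carbon with a double bond to nitrogen that has a five-membered aromatic ring, and in this assay it stays close to 4-methoxyphenyl, with a number 0.22 log units lower from compound 3 to compound 4 (within the scatter). Against the halogenated groups it separates, with a number 0.40 log units lower from compound 1 to compound 4 (beyond the scatter) and a number 1.44 log units lower from compound 2 to compound 4 (beyond the scatter), so a ring of 5 heavy atoms opens a gap from compound 1 that compound 3 did not. Nothing measured here accounts for these steps. The compounds shown leave open how an amine, a carboxylic acid or a saturated butyl chain at this carbon would read in this assay.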